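This account rests on a few compounds, and the source may have more. Where it says the series, first, only, none or still open, it means among the compounds named here.

Going by the values given here, in a functional assay on the whole organism with Scenedesmus acutus as the target, with a stated time of 20 h (on this read-out lower numbers stand for stronger inhibition and higher numbers for weaker inhibition), compound 1 (`CC(C)OC(=O)c1cc(N2C(=O)C3=C(CCCC3)C2=O)ccc1Cl`) gives 182 nM, the highest number of the three measured so far. Compound 2 (`CC(C)OC(=O)c1cc(N2C(=O)C3=C(CCCC3)C2=O)c(F)cc1Cl`) gives 89.1 nM and compound 3 (`CCC(C)OC(=O)c1cc(N2C(=O)C3=C(CCCC3)C2=O)c(F)cc1Cl`) gives 74.1 nM. Compound 4 (`CCCCCCCCOC(=O)c1cc(N2C(=O)C3=C(CCCC3)C2=O)ccc1Cl`) keeps the core of compound 1 and differs in one place: octyl in place of isopropyl on an oxygen next to a carbonyl group.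

The closest measured evidence is the methyl in place of hydrogen on the saturated chain, a 1.2-fold lower number from compound 2 to compound 3 (0.08 log units; within the scatter), which stays within the scatter. The fluoro in place of hydrogen on an aromatic carbon, a 2.0-fold lower number from compound 1 to compound 2 (0.31 log units; beyond the scatter), is a change at another place and bears on this one only weakly. Octyl is a far bigger replacement than a single methyl, and no measured compound carries a long chain, so the direction remains uncertain. A modest shift towards weaker inhibition is expected, estimated as a 1.5-fold higher number from compound 1 to compound 4 (0.19 log units; within the scatter). Compound 4 is estimated at 280 nM, with an expected range from 70 nM to 1100 nM.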

Compound 4, half-maximal inhibitory concentration: > 100000 nM
Compound 4: no number, only a limit; the forecaster's own chance of this, stated with the estimate: 8%; middle value at least 350-fold (2.55 log units) away from the limit.
By their numbers in this assay, from the lowest: compounds 3 and 2 (each within the scatter of the next); then compound 1. At a limit, above all of these: compound 4.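

In this assay, octyl in place of isopropyl on an oxygen next to a carbonyl group gives an at least 540-fold higher number from compound 1 to compound 4 (2.73 log units; beyond the scatter) and shows that this position is far from indifferent to the group it carries. Going by these compounds alone, the only earlier change on this chain (a 1.2-fold lower number from compound 2 to compound 3 (0.08 log units; within the scatter)) stayed within the scatter, so that small addition gave no sign of such a sharp drop in inhibition. For compound 4, the value is a limit of the assay and not a number: the limit of > 100000 nM in this assay, at which 1 of the 4 values shown sits.

The compounds shown leave open at what chain length inhibition falls away, which a butyl or hexyl chain on the same oxygen would help to place. They also leave open whether octyl has the same effect on the fluoro-bearing compound 2.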